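A Second Methoxy on the Anilino Ring

The source may report more compounds than this note shows. Statements on the series, on what has been measured and on what is new or still open speak of the compounds shown alone.

Compound 2 `COc1ccc(Nc2nc(SCc3ccc(C(F)(F)F)cc3)nc3ccccc23)cc1` is one of two measured analogues sharing the same core. In a functional assay on PC-3 cells (Homo sapiens) for cytotoxicity, read by MTT assay, with a stated time of 72 h (on this read-out higher numbers stand for weaker inhibition and lower numbers for stronger inhibition), compound 2 gives 16700 nM, the highest of the two numbers recorded. Its nearest neighbour is compound 1 `FC(F)(F)c1ccc(CSc2nc(Nc3cccc(Br)c3)c3ccccc3n2)cc1`, which in this assay gives 8680 nM; the step of a 1.9-fold higher number from compound 1 to compound 2 (0.28 log units; within the scatter) lies within the scatter, so the two compounds cannot be placed in order of potency on these data.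

Compound 3 `COc1ccc(Nc2nc(SCc3ccc(C(F)(F)F)cc3)nc3ccccc23)cc1OC` has not yet been measured. It differs from compound 2 by methoxy in place of hydrogen on an aromatic carbon, set ortho to a methoxy group and meta to a large group, so that the 4-methoxyphenyl becomes a 3,4-dimethoxyphenyl.

Within the data shown here, only one measured step bears on this change, a 1.9-fold higher number from compound 1 to compound 2 (0.28 log units; within the scatter), and it exchanged the whole substitution pattern of that aryl ring while moving the number no further than the scatter. Against that background, the expected step of a 1.0-fold lower number from compound 2 to compound 3 (0.02 log units; within the scatter) is estimated to stay within the scatter as well, with no direction that the data would support. Compound 3 is therefore expected to give about 16000 nM in this assay, within a range from 6000 nM to 45000 nM.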

Compound 3, half-maximal inhibitory concentration: 14100 nM
Compound 3: the middle estimate sits 1.1-fold (0.05 log units) above what was measured; measured number inside the range.
By their numbers in this assay, from the lowest: compounds 1, 3 and 2 (each within the scatter of the next).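

In this assay, setting a methoxy in place of hydrogen on an aromatic carbon, ortho to a methoxy group and meta to a large group, gives a 1.2-fold lower number from compound 2 to compound 3 (0.07 log units; within the scatter) and so shows that this position carries the added group without any shift the data can resolve. The 3,4-dimethoxyphenyl also sits with the 3-bromophenyl of the first analogue, at a 1.6-fold higher number from compound 1 to compound 3 (0.21 log units; within the scatter) and with every pair among the three compounds within the scatter, so neither the first aryl pattern nor the second methoxy separates itself on this read-out. Nothing measured alongside these numbers speaks to what lies behind them.

On these data alone, whether a group other than methoxy at this place, such as a hydroxyl, an amine, a carboxylic acid or a longer chain, would move the number beyond the scatter remains open. As far as these compounds go, the trifluoromethyl group is also the same in all three compounds, so what a nitrile in its place would do in this cell assay stays unknown as well.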